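A few compounds are considered here, and "the series" means these few. Any claim that something is new, unique, unknown or untested is made for them only; others in the source may bear on it.

Measured so far in a functional assay on EA.hy 926 cells (Homo sapiens) for cytotoxicity, read by MTT assay, with stated times of 24 h and 12 h; on this read-out higher numbers stand for an effect only at larger amounts of compound and lower numbers for an effect already at smaller amounts: compound 1 `Cc1nc(C)c(C(=O)Oc2ccccc2/C=C/C(=O)O)nc1C` gives 36700 nM; compound 2 `Cc1nc(C)c(C(=O)Oc2ccc(Cl)cc2/C=C/C(=O)O)nc1C` gives 95200 nM; compound 3 `CCOC(=O)/C=C/c1ccccc1OC(=O)c1nc(C)c(C)nc1C` gives 108000 nM.

Compound 4 `CCOC(=O)/C=C/c1cc(Cl)ccc1OC(=O)c1nc(C)c(C)nc1C` has not yet been measured. It differs from compound 3 by chloro in place of hydrogen on an aromatic carbon. The same kind of change separates compound 1 from compound 2, (chloro in place of hydrogen on an aromatic carbon), and there the step was a 2.6-fold higher number from compound 1 to compound 2 (0.41 log units; beyond the scatter). The surroundings are not identical: in compound 2 the chloro is meta to a 2-carboxyethenyl group, in compound 4 meta to a 2-(ethoxycarbonyl)ethenyl group. The two cores themselves differ by ethyl in place of hydrogen on an oxygen next to a carbonyl group, a step of a 2.9-fold higher number from compound 1 to compound 3 (0.47 log units; beyond the scatter). For compound 4 a step of a 2.4-fold higher number from compound 3 to compound 4 (0.38 log units; beyond the scatter) in this assay is expected, because the only comparable step, a 2.6-fold higher number from compound 1 to compound 2 (0.41 log units; beyond the scatter), was modest and the change occurs only twice among these compounds. Compound 4 is therefore estimated at 260000 nM, between 110000 nM and 600000 nM.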

Compound 4, half-maximal effective concentration: 36100 nM
The estimate for compound 4 lay 7.2-fold (0.86 log units) above the measured number; the measured number lies below the stated range.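

Chloro in place of hydrogen on an aromatic carbon gave a 3.0-fold lower number from compound 3 to compound 4 (0.48 log units; beyond the scatter) in this assay, and ethyl in place of hydrogen on an oxygen next to a carbonyl group gave a 2.6-fold lower number from compound 2 to compound 4 (0.42 log units; beyond the scatter). The chloro change therefore did not carry over from the core of compound 1 to the core of compound 3: the same change on two cores in this assay, a 2.6-fold higher number (0.41 log units; beyond the scatter) from compound 1 to compound 2 and a 3.0-fold lower number (0.48 log units; beyond the scatter) from compound 3 to compound 4, 7.8-fold (0.89 log units) apart, beyond the scatter of two such steps. Going by these compounds alone, the ethyl change likewise did not carry over, and with only two examples of each change, these four compounds show that neither step can be transferred here but not why: the same change on two cores in this assay, a 2.9-fold higher number (0.47 log units; beyond the scatter) from compound 1 to compound 3 and a 2.6-fold lower number (0.42 log units; beyond the scatter) from compound 2 to compound 4, 7.8-fold (0.89 log units) apart, beyond the scatter of two such steps.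

The compounds shown leave open whether fluoro or bromo in place of chloro would follow either step. They also leave open how a methyl ester or a longer ester chain would compare with the ethyl ester.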